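A few compounds are considered here, and "the series" means these few. Any claim that something is new, unique, unknown or untested is made for them only; others in the source may bear on it.

Measured so far, in a functional assay on HepG2 cells (Homo sapiens) for antiproliferative activity, read by MTT assay, with a stated time of 72 h; a higher number here means a weaker inhibitor, a lower number a stronger inhibitor: compound 1 `COc1ncc(-c2ccc3c(c2)N(c2ccc(C)cc2)C(=O)CO3)cc1NS(=O)(=O)c1ccc(F)cc1` gives 28300 nM; compound 2 `Cc1ccc(N2C(=O)COc3ccc(-c4cnc(Cl)c(NS(=O)(=O)c5ccc(F)cc5)c4)cc32)cc1` gives 39600 nM; compound 3 `COc1ccc(N2C(=O)COc3ccc(-c4cnc(OC)c(NS(=O)(=O)c5ccc(F)cc5)c4)cc32)cc1` gives 13100 nM.

Compound 4 `COc1ncc(-c2ccc3c(c2)N(c2ccc(Cl)cc2)C(=O)CO3)cc1NS(=O)(=O)c1ccc(F)cc1` is not yet measured. It differs from compound 3 by chloro in place of methoxy on an aromatic carbon. The cores of compound 1 and compound 3 differ by methoxy in place of methyl on an aromatic carbon, a change that gave a 2.2-fold lower number from compound 1 to compound 3 (0.33 log units; beyond the scatter). The same kind of change as from compound 3 to compound 4 has been made once before, from compound 1 to compound 2: chloro in place of methoxy on an aromatic carbon, giving a 1.4-fold higher number from compound 1 to compound 2 (0.15 log units; within the scatter). The places are not alike, though: in compound 1 the changed carbon sits in a six-membered aromatic ring with one nitrogen, next to the ring nitrogen and ortho to a ((4-fluorophenyl)sulfonyl)amino group, whereas in compound 3 it sits in a six-membered aromatic ring of carbon only. Because the earlier step of a 1.4-fold higher number from compound 1 to compound 2 (0.15 log units; within the scatter) stayed within the scatter, compound 4 is expected to stand close to compound 3, with a 1.3-fold higher number from compound 3 to compound 4 (0.11 log units; within the scatter). For compound 4 the estimate is 17000 nM, between 8000 nM and 36000 nM.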

Compound 4, half-maximal inhibitory concentration: 17900 nM
The estimate for compound 4 lay 1.1-fold (0.02 log units) below the measured number, within the range that was stated.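

In this assay the swap from 4-methoxyphenyl to 4-chlorophenyl gives a 1.4-fold higher number from compound 3 to compound 4 (0.14 log units; within the scatter) and so leaves compound 4 indistinguishable from compound 3, while the methyl-to-chloro swap gives a 1.6-fold lower number from compound 1 to compound 4 (0.20 log units; within the scatter) and likewise stays within the scatter. Chloro in place of methoxy looks the same on both cores: the same change on two cores in this assay, a 1.4-fold higher number (0.15 log units; within the scatter) from compound 1 to compound 2 and a 1.4-fold higher number (0.14 log units; within the scatter) from compound 3 to compound 4, 1.0-fold (0.01 log units) apart, within the scatter of two such steps. Both steps are too small to separate from the scatter and the change sits on a different ring in each pair, so this shows only that it did little in either place, not that a real effect carries from one core to another.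

Still open, on these data alone, is whether a different group on this phenyl ring, such as an amine or a carboxylic acid, would shift the number beyond the scatter.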